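The compounds below may be only part of what the source reports. "The series", "measured", "known", "first", "only" and "open" are said of these compounds alone.

Measured compounds in a functional assay on HT-29 cells (Homo sapiens) for cytotoxicity, read by MTT assay, with a stated time of 24 h, tested at 1.6 ug/mL; on this read-out higher numbers stand for a stronger effect at the one concentration tested and lower numbers for a weaker effect:
compound 1 `Cn1c(-c2ccc(NC(=O)CCl)cc2)nc(-c2ccccc2)c1-c1ccccc1` — 14.4%
compound 2 `Cc1nnc(SCC(=O)Nc2ccc(-c3nc(-c4ccccc4)c(-c4ccccc4)n3C)cc2)s1` — 39.9%
compound 3 `Cn1c(-c2ccc(NC(=O)CSC3=NCCS3)cc2)nc(-c2ccccc2)c1-c1ccccc1` — 30.4%

Compound 3 stands second highest of the three numbers. Its nearest neighbour is compound 2, with a number 9.5 percentage points lower from compound 2 to compound 3 (within the scatter), a gap that lies within the scatter; the furthest is compound 1, with a number 16 percentage points higher from compound 1 to compound 3 (beyond the scatter), a step beyond the scatter.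

Compound 4 `CN(C)/C=C/N1CCN(CC(=O)Nc2ccc(-c3nc(-c4ccccc4)c(-c4ccccc4)n3C)cc2)CC1` is not yet measured. It differs from compound 3 in one place: a group of 11 heavy atoms (8 carbon, 3 nitrogen; one six-membered non-aromatic ring with 2 hetero atoms) in place of a group of 6 heavy atoms (3 carbon, 1 nitrogen, 2 sulfur; one five-membered non-aromatic ring with 2 hetero atoms), on a saturated chain carbon bound to a carbonyl carbon

Three measured steps exist. Two of them, a number 25.5 percentage points higher from compound 1 to compound 2 (beyond the scatter) and a number 16 percentage points higher from compound 1 to compound 3 (beyond the scatter), concern the exchange of a chlorine for a larger group on the saturated chain carbon bound to the carbonyl carbon, and both were modest rises beyond the scatter. The third, a number 9.5 percentage points lower from compound 2 to compound 3 (within the scatter), swaps one ring-bearing group for another on the sulfur and stays within the scatter. For the measured compounds named here, none of the steps involves the entering 4-(2-(dimethylamino)ethenyl)piperazin-1-yl group, so the only direct guide is that exchanging one such group for another did not move the read-out beyond the scatter. The expectation for this assay is therefore a step of a number 0.4 percentage points lower from compound 3 to compound 4 (within the scatter), with no direction beyond the scatter. Compound 4 is estimated at 30%, with a range from 14% to 48%.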

Compound 4, a percentage reported as activity, at one concentration (the size of the read-out at that concentration, not a potency): 8%
The estimate for compound 4 lay 22 percentage points above the measured number, outside the stated range (below it).
By their numbers in this assay, from the lowest: compounds 4 and 1 (each within the scatter of the next); then compounds 3 and 2 (each within the scatter of the next).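

At the saturated chain carbon bound to a carbonyl carbon, the entering group can also take the read-out down in this assay: 4-(2-(dimethylamino)ethenyl)piperazin-1-yl gives a number 22.4 percentage points lower from compound 3 to compound 4 (beyond the scatter) and a number 31.9 percentage points lower from compound 2 to compound 4 (beyond the scatter), so this position is more sensitive to the group than the exchange between the two sulfur-bound groups had suggested. Against the chloro compound, the same group gives a number 6.4 percentage points lower from compound 1 to compound 4 (within the scatter), so a larger group in place of chloro does not by itself bring the rise seen with compound 2 and compound 3, and compound 4 goes against any such pattern. No measurement available here bears on what lies behind these steps.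

Going by these compounds, it remains open whether the piperazine ring or the dimethylamino-bearing ethenyl part carries the difference, which a plain piperazin-1-yl or a 4-methylpiperazin-1-yl group at the same carbon would separate. On these data alone, it also remains open whether the sulfur link itself matters, which a morpholin-4-yl group or a phenylsulfanyl group could begin to address.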